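The source may report more compounds than this note shows. Statements on the series, on what has been measured and on what is new or still open speak of the compounds shown alone.

Measured compounds:
- compound 1 `CC1CC/C(=N\Nc2ccc(Br)cc2)c2ncc(C(=O)O)c(=O)n21`; in a functional assay on the whole organism for inhibition, with Rattus norvegicus as the target (a higher number here means that more compound is needed for the effect, a lower number that less compound is needed), compound 1 gives only a limit, > 1000 umol/kg.
- compound 2 `C[C@@H]1CC/C(=N\Nc2ccc(O)cc2)c2ncc(C(=O)O)c(=O)n21`; in this assay compound 2 gives only a limit, > 100 umol/kg.
- compound 3 `CCOc1ccc(N/N=C2\CC[C@@H](C)n3c2ncc(C(=O)O)c3=O)cc1`; in this assay compound 3 gives only a limit, > 100 umol/kg.

Compound 1 stands at the limit of > 1000 umol/kg in this assay, at which 1 of the 3 values shown sits, while the two other values sit at the limit of > 100 umol/kg in this assay, at which 2 of the 3 values shown sit. None of the three is a number, so compound 1 cannot be placed against compound 2 or compound 3 beyond saying that all three fell short of the assay window.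

Going by the values given here, the single step within the measured set, a step that the two limits leave unreadable from compound 2 to compound 3, is unreadable from two limits and gives no size.

The unmeasured compound 4 `CCc1ccc(N/N=C2\CCC(C)n3c2ncc(C(=O)O)c3=O)cc1` differs from compound 1 by ethyl in place of bromo on an aromatic carbon. Among the compounds with values here, no measured step bears on an ethyl entering for a bromo, and the one step that exists, a step that the two limits leave unreadable from compound 2 to compound 3, carries no readable size. Within the data shown here, with every value in this assay a limit, the expectation is that compound 4 will also not reach a measurable dose, with no step readable beyond the scatter.

Compound 4 is therefore estimated at 1000 umol/kg in this assay, expected to lie between 300 umol/kg and 3000 umol/kg. The implied step, a number no higher from compound 1 to compound 4 (the limit leaves the size open), is expected to be no change, and most probably only another limit will be reported.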

Compound 4, dose for 50% inhibition: > 1000 umol/kg
Compound 4: no number, only a limit (the forecaster's own chance of this, stated with the estimate: 85%); the middle value sits exactly at the limit.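

In this assay compound 4 gives > 1000 umol/kg as a limit and not a number. Compound 1 also gives only a limit, so no step can be read between compound 1 and compound 4. The compounds shown leave open whether any member of this series reaches a measurable dose in this assay and how ethyl and bromo compare there.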